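The source may report more compounds than this note shows. Statements on the series, on what has been measured and on what is new or still open speak of the compounds shown alone.

Of the compounds shown here, three have so far been measured in a functional assay on T47D cells (Homo sapiens) for cytotoxicity, read by sulforhodamine B assay, with a stated time of 48 h, tested at 100 uM; a higher number here means a weaker effect of the compound at the concentration tested, a lower number a stronger effect. Compound 1, `COc1ccc(-c2cc(/C=C/C(=O)c3ccc(N)cc3)[nH]n2)cc1`, gives -54% in this assay. Compound 2, `COc1ccc(-c2cc(/C=C/C(=O)c3ccc(N)cc3)[nH]n2)cc1OC`, gives -40%. Compound 3, `COc1cc(C(=O)/C=C/c2cc(-c3cc(OC)c(OC)c(OC)c3)n[nH]2)cc(OC)c1OC`, gives -92%, the lowest of the three numbers, and its distance to each of the other two lies beyond the scatter. The difference between the core of compound 3 and the core of compound 2 is not broken down here.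

Compound 1 and compound 2 differ in a single place: hydrogen in place of methoxy on an aromatic carbon. That change made the step of a number 14 percentage points lower from compound 2 to compound 1 (beyond the scatter), a modest step that nonetheless exceeds the scatter.

Compound 4, `COc1ccc(-c2cc(/C=C/C(=O)c3cc(OC)c(OC)c(OC)c3)[nH]n2)cc1OC`, awaits measurement in this assay. It differs from compound 3 as follows: hydrogen in place of methoxy on an aromatic carbon. Among the compounds with values here, this is the same kind of change as the one between compound 2 and compound 1, though not the same: in compound 3 the carbon that loses its methoxy is also meta to a methoxy group, which is not so in compound 2.

Compound 4 is expected to give about -95%, between -102% and -84%, because compound 3 already stands at -92% and the earlier change of this kind made a number 14 percentage points lower from compound 2 to compound 1 (beyond the scatter). The expected step is therefore a number 3 percentage points lower from compound 3 to compound 4 (within the scatter), smaller than the earlier one, since compound 3 at -92% leaves little room for a further fall.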

Compound 4, a percentage reported as activity, at one concentration (the size of the read-out at that concentration, not a potency): -47%
The estimate for compound 4 lay 48 percentage points below the measured number; the measured number lies above the stated range.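

In this assay compound 3 gives -92% and compound 4 gives -47%, so putting hydrogen in place of methoxy on an aromatic carbon here brings a number 45 percentage points higher from compound 3 to compound 4 (beyond the scatter) and reverses the direction seen on the other core. Within the data shown here, this shows that, among the compounds measured so far, neither the size nor the direction of this change can be carried from one core to the other. Among these compounds, it does not show which difference between the two cores sets the steps apart, and with only two pairs it gives no rule for any further core. The two steps compare as follows: the same change on two cores in this assay, a number 14 percentage points lower (beyond the scatter) from compound 2 to compound 1 and a number 45 percentage points higher (beyond the scatter) from compound 3 to compound 4, 59 percentage points apart, beyond the scatter of two such steps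

The compounds shown carry only methoxy groups or hydrogen on the rings where this change was made, so it remains open how a hydroxyl group, a fluorine atom or a longer chain such as ethoxy would behave there on either core. From the compounds shown here alone, it also remains open whether the step would follow the pattern of compound 1 and compound 2 or that of compound 3 and compound 4 on a further core.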